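The source may report more compounds than this note shows. Statements on the series, on what has been measured and on what is new or still open speak of the compounds shown alone.

Measured so far in an assay for binding affinity to dual specificity mitogen-activated protein kinase kinase 4 (Homo sapiens), read by KINOMEscan, tested at 100 nM; a lower number here means a stronger effect, a higher number a weaker effect of the compound at the concentration tested:
Compound 1 `CCCS(=O)(=O)Nc1ccc(F)c(C(=O)c2n[nH]c3ncc(-c4cccc(F)c4)cc23)c1F` gives 8.2%.
Compound 2 `CCCS(=O)(=O)Nc1ccc(F)c(C(=O)c2n[nH]c3ncc(-c4cccc(OC)c4)cc23)c1F` gives 6.3%.
Compound 3 `CCCS(=O)(=O)Nc1ccc(F)c(C(=O)c2n[nH]c3ncc(-c4cccc(N)c4)cc23)c1F` gives 1.6%.

Compound 3 thus shows the lowest of the three numbers, yet its steps from the others, a number 6.6 percentage points lower from compound 1 to compound 3 (within the scatter) and a number 4.7 percentage points lower from compound 2 to compound 3 (within the scatter), like a number 1.9 percentage points lower from compound 1 to compound 2 (within the scatter), all lie within the scatter, so the three are read as alike. Compound 4 `CCCS(=O)(=O)Nc1ccc(F)c(C(=O)c2n[nH]c3ncc(-c4cc(Cl)cc(Cl)c4)cc23)c1F` differs from compound 3 by 3,5-dichlorophenyl in place of 3-aminophenyl on an aromatic carbon. Among the measured compounds shown here, no measured step covers this change directly; the earlier swaps of fluoro, methoxy and amino each gave steps within the scatter, but chlorine, and two substituents at once, are untested. The account therefore expects compound 4 to stay near the measured range, with a step of a number 8.4 percentage points higher from compound 3 to compound 4 (within the scatter), and estimates compound 4 at 10%, between 1% and 40%.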

Compound 4, a percentage reported as activity, at one concentration (the size of the read-out at that concentration, not a potency): 73%
Beside the measured number, compound 4's estimate is 63 percentage points below it, outside the stated range (above it).
By their numbers in this assay, from the lowest: compounds 3, 2 and 1 (each within the scatter of the next); then compound 4.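

In this assay, the 3-aminophenyl, 3-methoxyphenyl and 3-fluorophenyl groups had read alike at this position, which gave no sign that the read-out could move much here. The 3,5-dichlorophenyl group changes that, with a number 71.4 percentage points higher from compound 3 to compound 4 (beyond the scatter) and a number 66.7 percentage points higher from compound 2 to compound 4 (beyond the scatter) and a number 64.8 percentage points higher from compound 1 to compound 4 (beyond the scatter) as large steps towards a weaker effect. No evidence at hand accounts for this shift.

On these data alone, whether it goes with chlorine itself or with carrying two substituents stays open. A 3-chlorophenyl or a 3,5-difluorophenyl group would separate the two.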